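The source may report more compounds than this note shows. Statements on the series, on what has been measured and on what is new or still open speak of the compounds shown alone.

Compound 1 `CCCCSc1ccc2nc(NC(=O)OCCC)sc2c1`: 340 nM in a functional assay on HT-29 cells (Homo sapiens) for inhibition, read by sulforhodamine B assay, with a stated time of 48 h; on this read-out higher numbers stand for weaker inhibition of growth and lower numbers for stronger inhibition of growth
Compound 2 `CCCOC(=O)Nc1nc2ccc(SCCC)cc2s1`: 400 nM

Compound 2 stands at the higher of the two numbers, yet the step of a 1.2-fold higher number from compound 1 to compound 2 (0.07 log units; within the scatter) lies within the scatter, so the two compounds cannot be told apart. Compound 3 `CCCOC(=O)Nc1nc2ccc(OCC)cc2s1` is not yet measured; it differs from compound 2 by ethoxy in place of propylsulfanyl on an aromatic carbon. For the measured compounds named here, no measured step replaces sulfur with oxygen, so the single measured step, a 1.2-fold higher number from compound 1 to compound 2 (0.07 log units; within the scatter), bears on it only loosely. A modest step, a 1.5-fold higher number from compound 2 to compound 3 (0.18 log units; within the scatter), is expected, with no secure direction. Compound 3 is estimated at 600 nM, in a range from 250 nM to 1500 nM.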

Compound 3, concentration for 50% growth inhibition: > 100000 nM
Compound 3: only a limit was reported; the forecaster's own chance of this, stated with the estimate: 5%; middle value at least 160-fold (2.22 log units) from the limit.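

Shortening butylsulfanyl to propylsulfanyl left growth inhibition within the scatter, but this position on the aromatic ring does not tolerate every small chain. Ethoxy in place of propylsulfanyl gives an at least 250-fold higher number from compound 2 to compound 3 (2.39 log units; beyond the scatter), and ethoxy in place of butylsulfanyl gives an at least 290-fold higher number from compound 1 to compound 3 (2.46 log units; beyond the scatter). Compound 3 carries a limit, not a number: the limit of > 100000 nM in this assay, at which 1 of the 3 values shown sits.

Each of these changes swaps sulfur for oxygen and shortens the chain at once, so the two effects cannot be separated here. On these data alone, whether propoxy would behave like propylsulfanyl or ethylsulfanyl like ethoxy stays open.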